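A few compounds are considered here, and "the series" means these few. Any claim that something is new, unique, unknown or untested is made for them only; others in the source may bear on it.

Measured compounds:
- compound 1, `COC(=O)c1cccc(-c2cnc(C(=O)CCCCCCc3ccccc3)o2)c1`: 12 nM
- compound 2, `Nc1ccc(-c2cnc(C(=O)CCCCCCc3ccccc3)o2)cc1`: 90 nM
- compound 3, `COc1ncc(-c2cnc(C(=O)CCCCCCc3ccccc3)o2)c(OC)n1`: 26 nM

These three compounds share one core and differ only in the aromatic group attached to it. In an assay (Rattus norvegicus) for inhibition of Fatty-acid amide hydrolase 1 (Homo sapiens) (a lower number here means a stronger inhibitor, a higher number a weaker inhibitor), compound 1 gives 12 nM, compound 3 gives 26 nM, and compound 2 gives 90 nM. Compound 2 therefore stands highest of the three, that is, it is the weakest inhibitor of this set; its number lies above that of compound 3 and further above that of compound 1, and both gaps are larger than the scatter of repeated measurements.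

Compound 4, `O=C(CCCCCCc1ccccc1)c1ncc(-c2nnn[nH]2)o1`, has not yet been measured in this assay. It differs from compound 2 in one place: 1H-tetrazol-5-yl in place of 4-aminophenyl on an aromatic carbon. A group of seven heavy atoms with one six-membered ring is thus exchanged for a smaller group of five heavy atoms with one five-membered ring that is richer in hydrogen-bond acceptors.

Going by the values given here, no pair of measured compounds shows this kind of exchange, so the direction of the step is uncertain. The expectation is a step within or only slightly beyond the scatter, with a somewhat weaker inhibitor more likely than a stronger one, giving an expected 1.7-fold higher number from compound 2 to compound 4 (0.22 log units; within the scatter). For compound 4 the estimate in this assay is 150 nM, expected to fall between 40 nM and 600 nM.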

Compound 4, inhibition constant: 63 nM
For compound 4 the middle estimate is 2.4-fold (0.38 log units) above the measured one; the measured number falls inside the stated range.
By their numbers in this assay, from the lowest: compound 1; then compound 3; then compounds 4 and 2 (each within the scatter of the next).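

In this assay, putting 1H-tetrazol-5-yl in place of 4-aminophenyl gives a 1.4-fold lower number from compound 2 to compound 4 (0.15 log units; within the scatter), so at this position on the shared core the two groups cannot be told apart. This is the first compound shown with a five-membered aromatic ring at this carbon rather than a six-membered one, and the smaller group, with more nitrogen and more hydrogen-bond acceptors, leaves the number level with that of compound 2. No measurement here accounts for this outcome.

This single step changes ring size, heavy-atom count and hydrogen-bond acceptor count all at once, so the compounds shown cannot reveal whether any one of these matters on its own. On these data alone, it also remains open how the number would respond to a carboxylic acid at this carbon, or to a methyl group on a nitrogen of the tetrazole ring in place of its hydrogen.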